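The compounds below may be only part of what the source reports. "The series", "measured", "known", "first", "only" and "open" are said of these compounds alone.

In a functional assay on A2780 cells (Homo sapiens) for antiproliferative activity, read by sulforhodamine B assay, with a stated time of 48 h (a higher number here means a weaker inhibitor of growth, a lower number a stronger inhibitor of growth), compound 2 `Cc1ccc(S(=O)(=O)N2CCC(Cl)=CC2CC(C)C)cc1` gives 35000 nM, and compound 3 `Cc1ccc(S(=O)(=O)N2CCC(Br)=CC2CC(C)C)cc1`, with bromo in place of chloro on a double-bonded ring carbon, gives 36000 nM. That change, a 1.0-fold higher number from compound 2 to compound 3 (0.01 log units; within the scatter), leaves the number essentially where it was. Compound 1 `Cc1ccc(S(=O)(=O)N2CC[C@@H](Cl)C[C@@H]2c2ccccc2)cc1` reaches only a limit in this assay, > 100000 nM. Compound 3 and compound 2 thus sit within the scatter of each other, and the third value is a limit. Compound 4 `Cc1ccc(S(=O)(=O)N2CCC(Br)=CC2c2ccccc2)cc1` alters compound 3 by phenyl in place of isobutyl on a saturated ring carbon. Among the measured compounds shown here, no measured step swaps isobutyl for phenyl, and the halogen step does not bear on this change. Compound 1 also bears phenyl but lacks the ring double bond, so its limit and the number of compound 3 only hint that phenyl may give a higher number. For compound 4 the expected number in this assay is 70000 nM, within 25000 nM to 200000 nM. This estimate means an expected step of a 1.9-fold higher number from compound 3 to compound 4 (0.29 log units; within the scatter).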

Compound 4, concentration for 50% growth inhibition: 49000 nM
For compound 4 the middle estimate is 1.4-fold (0.15 log units) above the measured one, and the stated range covers the measured number.
By their numbers in this assay, from the lowest: compounds 2, 3 and 4 (each within the scatter of the next). At a limit, above all of these: compound 1.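

Replacing isobutyl (4 heavy atoms) with phenyl (6 heavy atoms, one aromatic ring) on this saturated ring carbon gives a 1.4-fold higher number from compound 3 to compound 4 (0.13 log units; within the scatter) in this assay. At this position, next to the ring nitrogen, a chain and an aromatic ring are therefore not told apart by this measurement. Nothing measured here gives a reason for this.

On these data alone, whether an amine, a carboxylic acid or a longer chain at this carbon would move the number beyond the scatter stays open. So does whether a substituted phenyl would.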